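The source may report more compounds than this note shows. Statements on the series, on what has been measured and on what is new or still open speak of the compounds shown alone.

Compound 1 `Cn1c(Cc2nn(C)c(=O)c3ccccc23)nnc1SCCCCCCCC(=O)Nc1ccc(F)cc1F`: "not determined" (no result reported)
Compound 2 `Cc1ccc(NC(=O)CCCCCCCSc2nnc(Cc3nn(C)c(=O)c4ccccc34)n2C)c(Cl)c1`: 24100 nM

Compound 1 stands without a number in an assay on isolated protein for binding affinity to interleukin-15 (Homo sapiens), read by surface plasmon resonance (on this read-out higher numbers stand for weaker binding and lower numbers for tighter binding), so nothing anchors it. Compound 2 is the only measured point, and in this assay compound 2 gives 24100 nM, a weak binding. Compound 3 `CCCOc1ccc(NC(=O)CCCCCCCSc2nnc(Cc3nn(C)c(=O)c4ccccc34)n2C)cc1` differs from compound 1 by 4-propoxyphenyl in place of 2,4-difluorophenyl on an amide-type nitrogen. Within the data shown here, with no measured step for this change, the expected shift is set at none beyond the scatter, in no firm direction. Compound 3 is therefore estimated to give 25000 nM, within 6000 nM to 100000 nM.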

Compound 3, dissociation constant: 19000 nM
Estimate against measurement, compound 3: 1.3-fold (0.12 log units) above, and the stated range covers the measured number.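

In this assay, the group on the amide-type nitrogen now has a measured step: 4-propoxyphenyl in place of 2-chloro-4-methylphenyl gives a 1.3-fold lower number from compound 2 to compound 3 (0.10 log units; within the scatter). This exchange of substituted phenyl groups therefore leaves the read-out unresolved, and binding remains weak with both. No evidence available here bears on this result.

Compound 1 stands at "not determined" (no result reported), so its 2,4-difluorophenyl group remains unplaced against the other two. Also open, going by these compounds, is how a carboxylic acid or an amine would read in place of these groups on the amide-type nitrogen.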